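Trading a halogenated aryl group for a dimethylphenyl group

The compounds below may be only part of what the source reports. "The series", "measured", "known", "first", "only" and "open" are said of these compounds alone.

Of the compounds shown here, three sharing one core have been measured in a functional assay on HepG2 cells (Homo sapiens) for antiproliferative activity, read by spectrophotometry, with a stated time of 2 days; on this read-out lower numbers stand for stronger inhibition of growth and higher numbers for weaker inhibition of growth. Compound 1 `CN(c1cccc2c1CN(c1nc(Nc3ccc(C(F)(F)F)cc3)ncc1C(F)(F)F)C2)S(C)(=O)=O` reaches only the limit of the assay, > 30000 nM, so no number is known for it (the limit of > 30000 nM in this assay, at which 1 of the 3 values shown sits). Compound 2 `COc1cc(Nc2ncc(C(F)(F)F)c(N3Cc4cccc(N(C)S(C)(=O)=O)c4C3)n2)cc(OC)c1` gives 1800 nM, and compound 3 `CN(c1cccc2c1CN(c1nc(Nc3cc(Cl)cc(C(F)(F)F)c3)ncc1C(F)(F)F)C2)S(C)(=O)=O` gives 9900 nM, the highest of the two numbers shown. The steps tell how the aryl group on the ring nitrogen matters: an at least 16-fold lower number from compound 1 to compound 2 (1.22 log units; beyond the scatter), an at least 3.0-fold lower number from compound 1 to compound 3 (0.48 log units; beyond the scatter), and a 5.5-fold higher number from compound 2 to compound 3 (0.74 log units; beyond the scatter).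

Compound 4 `Cc1cc(C)cc(Nc2ncc(C(F)(F)F)c(N3Cc4cccc(N(C)S(C)(=O)=O)c4C3)n2)c1` is not yet measured. Its change from compound 3 is 3,5-dimethylphenyl in place of 3-chloro-5-(trifluoromethyl)phenyl on a nitrogen on an aromatic ring. Within the data shown here, the only measured step that bears on it is the one from compound 2 to compound 3, where a 3,5-disubstituted phenyl carrying two methoxy groups gave the lower number and the 3-chloro-5-(trifluoromethyl)phenyl gave the higher one. Among the measured compounds shown here, compound 4 also carries a 3,5-disubstituted phenyl, with methyl groups instead, so a step back toward the number of compound 2 is expected, though methyl and methoxy are not the same group and no pair here separates them. For compound 4 the expected step is a 2.8-fold lower number from compound 3 to compound 4 (0.45 log units; beyond the scatter). Compound 4 is therefore estimated at 3500 nM, within a range from 1200 nM to 10000 nM.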

Compound 4, concentration for 50% growth inhibition: > 30000 nM
Compound 4 was reported as a limit (the forecaster's own chance of this, stated with the estimate: 5%); middle value at least 8.5-fold (0.93 log units) away from the limit.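

In this assay, the 3,5-dimethylphenyl group on a nitrogen on an aromatic ring, in place of 3,5-dimethoxyphenyl, gives an at least 16-fold higher number from compound 2 to compound 4 (1.22 log units; beyond the scatter), so a phenyl substituted in the 3 and 5 positions is not enough by itself to give a number like that of compound 2. The step to 3,5-dimethylphenyl from 3-chloro-5-(trifluoromethyl)phenyl gives an at least 3.0-fold higher number from compound 3 to compound 4 (0.48 log units; beyond the scatter), which means that among these two groups the halogenated one has the lower number, and that methyl groups cannot simply stand in for methoxy groups here. Compound 1 and compound 4 are both limits rather than numbers, so the step between them cannot be read: the limit of > 30000 nM in this assay, at which 2 of the 4 values shown sit.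

As far as these compounds go, what remains open is which part of the methoxy groups goes with the lower number of compound 2, a question that a phenyl carrying a single methoxy group, or one carrying two ethoxy, hydroxyl or amine groups, would help to address. From the compounds shown here alone, it is also open whether the order of these aryl groups would hold if the methanesulfonyl group on the shared core were replaced by an acetyl group.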